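Methyl-to-Hydrogen Step Repeated on a Second Core

The compounds below may be only part of what the source reports. "The series", "measured", "known", "first", "only" and "open" are said of these compounds alone.

The measured compounds and their values:
Compound 1, `CN(c1ccc(Oc2ncnc3ccsc23)cc1)c1nccc(N2CCc3ccccc3C2)n1`, gives 16200 nM.
Compound 2, `CN(c1ccc(Oc2ncnc3sccc23)cc1)c1nccc(N2CCCC2)n1`, gives 15100 nM.
Compound 3, `c1ccc2c(c1)CCN(c1ccnc(Nc3ccc(Oc4ncnc5ccsc45)cc3)n1)C2`, gives 17000 nM.

All three were tested in a functional assay on A549 cells (Homo sapiens) for inhibition, read by MTT assay, with a stated time of 72 h; a higher number here means a weaker inhibitor, a lower number a stronger inhibitor. The three numbers sit close together: compound 2 has the lowest of them, and its gap to compound 1 and to compound 3 is each within the scatter, so no order among the three can be read from these data.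

Compound 1 and compound 3 share a core and differ by a single change, (hydrogen in place of methyl on a nitrogen on an aromatic ring). This change made a step of a 1.0-fold higher number from compound 1 to compound 3 (0.02 log units; within the scatter), that is, no change that can be told apart from repeat measurement.

Compound 2 stands on a different core; how the core of compound 2 differs from that of compound 1 is not broken down here.

Compound 4, `c1cc(N2CCCC2)nc(Nc2ccc(Oc3ncnc4sccc34)cc2)n1`, has not yet been measured. Going by the values given here, it differs from compound 2 by hydrogen in place of methyl on a nitrogen on an aromatic ring, the same kind of change as the one from compound 1 to compound 3, made in the same kind of place. Since the earlier step was a 1.0-fold higher number from compound 1 to compound 3 (0.02 log units; within the scatter), the expected step from compound 2 to compound 4 in this assay is estimated at a 1.0-fold higher number from compound 2 to compound 4 (0.01 log units; within the scatter), resting on that single precedent and on the value of compound 2, 15100 nM. On that basis compound 4 is estimated to give 15500 nM, with a plausible range from 7000 nM to 34000 nM.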

Compound 4, half-maximal inhibitory concentration: 8100 nM
Beside the measured number, compound 4's estimate is 1.9-fold (0.28 log units) above it, and the stated range covers the measured number.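

In this assay, putting hydrogen in place of methyl on a nitrogen on an aromatic ring gave a 1.9-fold lower number from compound 2 to compound 4 (0.27 log units; within the scatter), and setting this beside the earlier case shows how the change behaves on the two cores: the same change on two cores in this assay, a 1.0-fold higher number (0.02 log units; within the scatter) from compound 1 to compound 3 and a 1.9-fold lower number (0.27 log units; within the scatter) from compound 2 to compound 4, 2.0-fold (0.29 log units) apart, within the scatter of two such steps. The two steps therefore cannot be told apart, and neither stands clear of repeat measurement, so the result agrees with the change carrying over from the core of compound 1 to the core of compound 2 with no effect that these data can resolve. It does not show that the change is without effect in this series, that one core responds differently from the other, or that the same would hold on any further core, since the account rests on just two matched pairs, each with a single value per compound.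

The compounds shown carry only methyl or hydrogen on this nitrogen, so it remains open whether a longer chain such as ethyl, or a larger group such as acetyl, would give a step that could be told from the scatter. They also leave open whether the step would look the same in any test other than this assay.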